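The source may hold more compounds than are shown below. What is called first, only, known or untested is meant among the compounds shown, and "the series" means these compounds.

Measured so far:
In an ADME assay on HepG2 cells (Homo sapiens) for cytotoxicity, read by luminescence, CellTiter-Glo and ATP content, with a stated time of 72 h (on this read-out lower numbers stand for an effect already at smaller amounts and higher numbers for an effect only at larger amounts of compound), compound 1 `COc1ccccc1Oc1ccc2c(NCCCNCc3ccco3)ccnc2c1` gives 6500 nM.
In this assay, compound 2 `Cc1cc(C)cc(Cc2ccc3c(NCCCNCc4ccco4)ccnc3c2)c1` gives 6270 nM.
In this assay, compound 3 `FC(F)(F)c1cccc(Cc2ccc3c(NCCCNCc4ccco4)ccnc3c2)c1` gives 3190 nM.

Compound 3 holds the lowest of the three numbers. Its nearest neighbour is compound 2, and the gap between them lies within the scatter, so no order between the two can be claimed; only the gap to compound 1 lies beyond the scatter.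

The step to compound 4 `N#Cc1ccc(Cc2ccc3c(NCCCNCc4ccco4)ccnc3c2)cc1` is 4-cyanophenyl in place of 3-(trifluoromethyl)phenyl on a saturated chain carbon bound to an aromatic carbon. The measured step that bears most directly on it is a 2.0-fold lower number from compound 2 to compound 3 (0.29 log units; within the scatter), a swap at the same place on the saturated chain carbon, which stayed within the scatter. The other step, a 1.0-fold lower number from compound 1 to compound 2 (0.02 log units; within the scatter), a swap at a different place, was also within the scatter. The shared core with its furan-containing chain is unchanged throughout, and both swaps of the aromatic group so far moved the read-out little.

For compound 4 the expectation is therefore a step of about a 1.4-fold higher number from compound 3 to compound 4 (0.15 log units; within the scatter), which is no more than the scatter, with the estimate centred at 4500 nM and a range from 2000 nM to 10000 nM.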

Compound 4, half-maximal effective concentration in the HepG2 assay: 7910 nM
Compound 4: middle estimate off by 1.8-fold (0.24 log units), on the low side, within the range that was stated.
By their numbers in the HepG2 assay, from the lowest: compounds 3, 2, 1 and 4 (each within the scatter of the next, the first and the last beyond it).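

For the compounds shown here, in the HepG2 assay this swap on the saturated chain carbon bound to an aromatic carbon gives a 2.5-fold higher number from compound 3 to compound 4 (0.39 log units; beyond the scatter) as the first step at this place beyond the scatter, whereas a 1.3-fold higher number from compound 2 to compound 4 (0.10 log units; within the scatter) and a 1.2-fold higher number from compound 1 to compound 4 (0.09 log units; within the scatter) both stay within it. In a physicochemical assay for acid dissociation, compound 3 gives 9.47 and compound 4 gives 9.47 as well, which amounts to no change at the digits printed from compound 3 to compound 4 (within the scatter) and so offers no parallel to the shift in the cytotoxicity read-out. Nothing at hand accounts for that shift.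

Open, going by these compounds, is whether the shift follows the nitrile itself or its ring position, a question that 3-cyanophenyl and 4-(trifluoromethyl)phenyl at this place could separate. Also open, on these data alone, is how a phenyl group bearing an amine or a carboxylic acid would read here.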